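Moving from dichloro to bromo on the sulfonamide pyridine

The compounds below may be only part of what the source reports. "The series", "measured", "known", "first", "only" and "open" are said of these compounds alone.

Compound 2 `O=S(=O)(CSc1nnc(Br)n1Cc1ccc(Br)c2ccccc12)Nc1cc(Cl)cnc1Cl` gives the higher of the two numbers in an assay on HEK293 cells for inhibition of solute carrier family 22 member 12 (Homo sapiens) (on this read-out lower numbers stand for stronger inhibition and higher numbers for weaker inhibition), with 2790 nM, whereas compound 1 `O=S(=O)(CSc1nnc(Br)n1Cc1ccc(Br)c2ccccc12)Nc1cccnc1` gives 32 nM. Compound 3 `O=S(=O)(CSc1nnc(Br)n1Cc1ccc(Br)c2ccccc12)Nc1cccnc1Br` differs from compound 2 by 2-bromopyridin-3-yl in place of 2,5-dichloropyridin-3-yl on a sulfonamide nitrogen. For the measured compounds named here, the only step that bears on this change is an 87-fold higher number from compound 1 to compound 2 (1.94 log units; beyond the scatter), and compound 3 undoes part of that same change. A lower number than for compound 2 is therefore expected, though not a full return to compound 1, with an estimated step of a 7.0-fold lower number from compound 2 to compound 3 (0.84 log units; beyond the scatter). For compound 3 the expected value in this assay is 400 nM, within a range from 80 nM to 2000 nM.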

Compound 3, half-maximal inhibitory concentration: 280 nM
Beside the measured number, compound 3's estimate is 1.4-fold (0.15 log units) above it, and the stated range covers the measured number.
By their numbers in this assay, from the lowest: compound 1; then compound 3; then compound 2.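

In this assay the swap to 2-bromopyridin-3-yl on the sulfonamide nitrogen gives a 10-fold lower number from compound 2 to compound 3 (1.00 log units; beyond the scatter) and so shows that a halogen-bearing pyridine here need not reach the number of the 2,5-dichloropyridin-3-yl compound. Bromo in place of hydrogen on an aromatic carbon still gives an 8.8-fold higher number from compound 1 to compound 3 (0.94 log units; beyond the scatter) on its own, and the unsubstituted pyridin-3-yl keeps the lowest number of the three. No available evidence accounts for either step. From the compounds shown here alone, whether a fluoro, methyl or methoxy group at the bromo's place would stay nearer compound 1 remains open.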